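Shortening the phosphate chain in compounds 1 to 4

This account rests on a few compounds, and the source may have more. Where it says the series, first, only, none or still open, it means among the compounds named here.

Measured in an in vitro functional assay on 1321-N1 cells for agonist activity at P2Y purinoceptor 2 (Homo sapiens); a lower number here means that less compound is needed, a higher number that more compound is needed for the effect:
compound 1, `Cn1c(=O)ccn([C@@H]2O[C@H](COP(=O)(O)OP(=O)(O)OP(=O)(O)O)[C@@H](O)[C@H]2O)c1=O`: 564 nM
compound 2, `Cn1c(=O)ccn([C@@H]2O[C@H](COP(=O)(O)OP(=O)(O)O)[C@@H](O)[C@H]2O)c1=O`: > 1000 nM, which is a limit of the assay and not a number
compound 3, `O=c1[nH]c(=O)n([C@@H]2O[C@H](COP(=O)(O)OP(=O)(O)O)[C@@H](O)[C@H]2O)cc1Br`: 3670 nM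

Compound 3 gives the highest of the two numbers in this assay; compound 1 gives the lower one. The difference between the core of compound 1 and the core of compound 3 is not broken down here.

From compound 1 to compound 2 the change is a hydrogen atom in place of a group of 4 heavy atoms (3 oxygen, 1 phosphorus; no ring), on an oxygen; the step is an at least 1.7-fold higher number from compound 1 to compound 2 (0.24 log units; that floor lies within the scatter), with compound 2 sitting at the limit of > 1000 nM in this assay, at which 1 of the 3 values shown sits.

Compound 4, `O=c1[nH]c(=O)n([C@@H]2O[C@H](COP(=O)(O)O)[C@@H](O)[C@H]2O)cc1Br`, is not yet measured. It differs from compound 3 by a hydrogen atom in place of a group of 4 heavy atoms (3 oxygen, 1 phosphorus; no ring), on an oxygen, the same change as from compound 1 to compound 2, made at the same place. The step to compound 4 is expected to be a 5.4-fold higher number from compound 3 to compound 4 (0.74 log units; beyond the scatter), resting on an at least 1.7-fold higher number from compound 1 to compound 2 (0.24 log units; that floor lies within the scatter) and on compound 3 already standing at 3670 nM. Compound 4 is therefore estimated at 20000 nM, between 5000 nM and 100000 nM, with a real chance that only a limit is reported.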

Compound 4, half-maximal effective concentration: > 1000 nM
Compound 4: only a limit was reported; the forecaster's own chance of this, stated with the estimate: 70%; the middle value is on the limit's open side.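

Compound 4 gives > 1000 nM, a limit of the assay and not a number, so the step from compound 3 to compound 4 cannot be read. From the compounds shown here alone, whether shortening the phosphate chain changes the number by a similar amount on the cores of compound 1 and compound 3 remains open.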